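The source may report more compounds than this note shows. Statements on the series, on what has been measured and on what is new or still open speak of the compounds shown alone.

Measured so far, in a functional assay on Jurkat cells (Homo sapiens) for antiproliferative activity, read by WST assay, with a stated time of 72 h; on this read-out lower numbers stand for stronger inhibition and higher numbers for weaker inhibition:

Compound 1 `Clc1ccc2[nH]c(-c3nc(-c4ccccc4)no3)cc2c1` gives > 50000 nM, a limit of the assay.
Compound 2 `Clc1ccc(-c2noc(-c3cc4cc(Cl)ccc4[nH]3)n2)cc1` gives > 50000 nM, a limit of the assay.
Compound 3 `COc1ccc(-c2noc(-c3cc4cc(OC)ccc4[nH]3)n2)cc1` gives > 50000 nM, a limit of the assay.

Compound 3 therefore stands at the same limit as the two other measured compounds, and no number is known for it. For the measured compounds named here, the only measured step between single-change neighbours, a step that the two limits leave unreadable from compound 1 to compound 2, is itself unreadable, since both of its ends sit at the limit; the shared picture is summed up by the limit of > 50000 nM in this assay, at which 3 of the 3 values shown sit.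

Compound 4 `COc1ccc(-c2noc(-c3cc4cc(Cl)ccc4[nH]3)n2)cc1` differs from compound 3 in one place: chloro in place of methoxy on an aromatic carbon. Going by the values given here, no measured step bears directly on this exchange, and the one step that exists gives no size. With nothing in this assay showing a shift away from the limit, the expected step that the limit leaves unreadable from compound 3 to compound 4 is none beyond the scatter. Compound 4 is therefore estimated at 80000 nM, within a range from 20000 nM to 300000 nM, most likely reported again only as a limit.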

Compound 4, half-maximal inhibitory concentration: > 50000 nM
Compound 4 ended at the assay's limit; the forecaster's own chance of this, stated with the estimate: 85%; the middle value does not contradict the limit.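

Compound 4 gives > 50000 nM in this assay, a limit of the assay and not a number. For the compounds shown here, no step from compound 1, compound 2 or compound 3 to compound 4 can therefore be read: the limit of > 50000 nM in this assay, at which 4 of the 4 values shown sit. The compounds shown leave open how they rank against one another, and whether any change to the shared core would give a measurable value.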